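The compounds below may be only part of what the source reports. "The series", "measured", "known", "first", "only" and "open" are said of these compounds alone.

Measured so far:
Compound 1, `COc1cc(/C(Cl)=C/C=C(\C#N)C(=O)c2c[nH]c3ccccc23)cc(OC)c1OC` — 54200 nM in an ADME assay on Vero cells (Chlorocebus sabaeus) for cytotoxicity, read by sulforhodamine B assay, with a stated time of 48 h; a lower number here means that less compound is tolerated, a higher number that more compound is tolerated.
Compound 2, `COc1ccc(/C(Cl)=C/C=C(\C#N)C(=O)c2c[nH]c3ccccc23)cc1OC` — "not determined" (no result reported) in this assay.

Going by the values given here, compound 1 stands alone on the numbers: it carries the only value, and compound 2 has no result at all, so nothing can be said of how the two compare. The piece now moves from compound 1 to compound 3, `COc1ccc2[nH]cc(C(=O)/C(C#N)=C/C=C(\Cl)c3cc(OC)c(OC)c(OC)c3)c2c1`, which is not yet measured. The two structures differ in one place: methoxy in place of hydrogen on an aromatic carbon. In the shared core this is a small addition, one methoxy group on the six-membered aromatic ring of the fused two-ring system, while the rest of compound 1 is kept. Among the compounds with values here, no step between two measured compounds is available to show what such an addition does, so the expectation rests on the one value of compound 1 and on the smallness of the change. The step from compound 1 to compound 3 is expected to stay within the usual scatter, with no clear direction, so that a 1.1-fold lower number from compound 1 to compound 3 (0.04 log units; within the scatter) is the estimated outcome. For compound 3 the value in this assay is therefore estimated at 50000 nM, in a range from 20000 nM to 125000 nM.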

Compound 3, concentration lethal to 50% of the cells: 45200 nM
Beside the measured number, compound 3's estimate is 1.1-fold (0.04 log units) above it; the range from low to high includes it.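

In this assay, methoxy in place of hydrogen on this aromatic carbon gives a 1.2-fold lower number from compound 1 to compound 3 (0.08 log units; within the scatter), so the two compounds cannot be told apart. Going by these compounds alone, this is the first pair that can be read at all, since compound 2 has no result, and it shows that at this one place, meta to a fused ring and para to a fused ring, adding methoxy to the core of compound 1 leaves no difference that stands out from the normal variation between repeated measurements. Nothing measured here speaks to the reason for this outcome.

On these data alone, it remains open whether another group at the same place, such as an amine, a carboxylic acid or a longer chain like butoxy, would also leave the number within the scatter. Within the data shown here, also open is whether methoxy on another carbon of the same six-membered ring, or on a different parent compound, would behave in the same way, as one pair of compounds describes only this single change and cannot establish a general pattern.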